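The source may hold more compounds than are shown below. What is called first, only, known or untested is meant among the compounds shown, and "the series" means these compounds.

Compound 2 `COc1ccccc1/C=C/C(=O)Nc1ccc2ncnc(Nc3cccc(Br)c3)c2c1` carries a 2-methoxyphenyl group on the double-bonded chain that links to the shared core. Within the data shown here, in a functional assay on B16-F10 cells (Mus musculus) for inhibition, read by MTT assay, with a stated time of 48 h (on this read-out lower numbers stand for stronger inhibition and higher numbers for weaker inhibition), compound 2 gives 1.28 ug/mL, the lower of the two numbers measured so far. Among the measured compounds shown here, its only neighbour is compound 1 `O=C(/C=C/c1ccccc1Cl)Nc1ccc2ncnc(Nc3cccc(Br)c3)c2c1`, which in this assay gives 2 ug/mL; the step of a 1.6-fold lower number from compound 1 to compound 2 (0.19 log units; within the scatter) is within the scatter, so the two compounds cannot be told apart on this read-out. Compound 3 `O=C(/C=C/c1ccc([N+](=O)[O-])cc1)Nc1ccc2ncnc(Nc3cccc(Br)c3)c2c1` has not yet been measured. It differs from compound 2 in one place: 4-nitrophenyl in place of 2-methoxyphenyl on a double-bonded chain carbon bound to a double-bonded chain carbon. For the measured compounds named here, only one measured step exists, and it swapped chloro for methoxy while keeping the same ring, not the whole ring substituent; that step was small. Nothing measured speaks directly to a nitro group, so the expectation rests on that single small step: no change beyond the scatter in this assay, in either direction. Compound 3 is therefore estimated at 1.5 ug/mL, with a range from 0.5 ug/mL to 5 ug/mL, which corresponds to an expected step of a 1.2-fold higher number from compound 2 to compound 3 (0.07 log units; within the scatter).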

Compound 3, half-maximal inhibitory concentration: 0.982 ug/mL
Compound 3: the middle estimate sits 1.5-fold (0.18 log units) above what was measured; the range from low to high includes it.
By their numbers in this assay, from the lowest: compounds 3, 2 and 1 (each within the scatter of the next, the first and the last beyond it).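

This position now has a change of the whole ring group rather than of one substituent on the same ring, and in this assay that swap gives a 1.3-fold lower number from compound 2 to compound 3 (0.12 log units; within the scatter), so compound 2 and compound 3 cannot be told apart. The first difference beyond the scatter appears only in the other pair, a 2.0-fold lower number from compound 1 to compound 3 (0.31 log units; beyond the scatter), and even that step is modest; it also replaces 2-chlorophenyl with 4-nitrophenyl, so both the group on the ring and its place in the name differ at once. Across these three compounds, the position accepts a 2-chlorophenyl, a 2-methoxyphenyl or a 4-nitrophenyl group with only this small spread in the numbers, and nothing available explains the modest step.

The compounds shown cannot separate the effect of the nitro group from the effect of where it sits on the ring. They also leave open how a plain unsubstituted phenyl ring would read here, or a phenyl ring carrying an amine or a carboxylic acid, and whether the narrow spread would hold for these groups.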